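Moving the amine on the short chain of compound 3

A few compounds are considered here, and "the series" means these few. Any claim that something is new, unique, unknown or untested is made for them only; others in the source may bear on it.

In a functional assay on cells for antagonist activity at C-X-C chemokine receptor type 4 (Homo sapiens), read by fluorescence and calcium flux, with stated times of 25 min and 90 s (a higher number here means a weaker inhibitor, a lower number a stronger inhibitor), compound 3 `CC(C)(CN)CCN(C[C@H]1Cc2ccccc2CN1)[C@H]1CCCc2cccnc21` gives 69 nM. Among the three compounds with numbers, compound 3 stands second highest: compound 1 `O=S1(=O)CCC(NCCCCN(C[C@H]2Cc3ccccc3CN2)[C@H]2CCCc3cccnc32)CC1` gives 45.5 nM in this assay, and compound 2 `CC1(C)CCC(NCCCCN(C[C@H]2Cc3ccccc3CN2)[C@H]2CCCc3cccnc32)CC1` gives 77.6 nM. All three sit within the scatter of one another, so no order can be read from them.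

Compound 4 `CC(C)(N)CCCN(C[C@H]1Cc2ccccc2CN1)[C@H]1CCCc2cccnc21` has the same atoms as compound 3, joined differently: 2-amino-2-methylpropyl in place of 1-(aminomethyl)-1-methylethyl on a saturated chain carbon, two bonds along the chain from an amine nitrogen. The steps measured so far concern the same position but a different kind of change, the replacement of a six-membered ring group by the small chain amine: a 1.5-fold higher number from compound 1 to compound 3 (0.18 log units; within the scatter) and a 1.1-fold lower number from compound 2 to compound 3 (0.05 log units; within the scatter), both within the scatter, as is a 1.7-fold higher number from compound 1 to compound 2 (0.23 log units; within the scatter). Among the measured compounds shown here, no measured step shifts the amine along the chain as the change to compound 4 does, so the data offer no direct guide, only the observation that variation at this position has so far moved this assay little.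

Compound 4 is therefore expected to give about 80 nM in this assay, in a range from 35 nM to 180 nM. This estimate corresponds to an expected step of a 1.2-fold higher number from compound 3 to compound 4 (0.06 log units; within the scatter), which is expected to stay within the scatter.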

Compound 4, half-maximal inhibitory concentration: 24.6 nM
For compound 4 the middle estimate is 3.3-fold (0.51 log units) above the measured one; the measured number lies below the stated range.
By their numbers in this assay, from the lowest: compounds 4, 1, 3 and 2 (each within the scatter of the next, the first and the last beyond it).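

Moving the amine, with 2-amino-2-methylpropyl in place of 1-(aminomethyl)-1-methylethyl, gives the first step beyond the scatter between the small chain amines in this assay: a 2.8-fold lower number from compound 3 to compound 4 (0.45 log units; beyond the scatter), although the two groups count the same atoms, donors and acceptors. So how the same atoms are joined at this position changes the number more than replacing the six-membered ring group with 1-(aminomethyl)-1-methylethyl did. The new chain also separates from one ring-bearing compound, with a 3.2-fold lower number from compound 2 to compound 4 (0.50 log units; beyond the scatter), but not from the other, with a 1.8-fold lower number from compound 1 to compound 4 (0.27 log units; within the scatter), so compound 4 cannot be called the strongest of the four. Nothing available explains the effect of this shift.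

The compounds shown offer only this one pair of chain amines with the same atoms, so it remains open whether a similar step would appear with the two methyl groups removed or with a longer chain carrying the same amine. From the compounds shown here alone, it is also open whether a hydroxyl group in place of the amine of compound 4 would keep a number close to that of compound 4.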